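This account rests on a few compounds, and the source may have more. Where it says the series, first, only, none or still open, it means among the compounds named here.

Measured compounds:
compound 1 `Nc1cc(Oc2ccc(NC(=O)Nc3cccc(C(F)(F)F)c3)cc2)ncn1` — 25 nM
compound 2 `CCc1cc(NC(=O)Nc2cccc(C(F)(F)F)c2)cc(Cl)c1Oc1cc(NC)ncn1` — <= 10 nM (a limit)
compound 3 `CNc1cc(Oc2ccc(NC(=O)Nc3cccc(C(F)(F)F)c3)c(F)c2F)ncn1` — 20 nM

In an assay on isolated protein for inhibition of serine/threonine-protein kinase TNNI3K (Homo sapiens) (on this read-out lower numbers stand for stronger inhibition and higher numbers for weaker inhibition), compound 1 gives 25 nM, the higher of the two plain numbers. Compound 3 gives 20 nM, a gap that lies within the usual scatter, so the two cannot be told apart. Compound 2 is reported only as a limit of the assay (the limit of <= 10 nM in this assay, at which 1 of the 3 values shown sits). Compound 4 `CC(C)CNc1cc(Oc2ccc(NC(=O)Nc3cccc(C(F)(F)F)c3)cc2)ncn1` differs from compound 1 in one place: isobutyl in place of hydrogen on a nitrogen on an aromatic ring. For the measured compounds named here, no measured pair shows this exact change, so its effect is not known from these data. The step from compound 1 to compound 4 is expected to be small, a 1.3-fold lower number from compound 1 to compound 4 (0.10 log units; within the scatter), staying close to compound 1. Compound 4 is therefore estimated at 20 nM, with a range from 5 nM to 80 nM.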

Compound 4, half-maximal inhibitory concentration: 50 nM
Compound 4: middle estimate off by 2.5-fold (0.40 log units), on the low side; measured number inside the range.
By their numbers in this assay, from the lowest: compounds 3, 1 and 4 (each within the scatter of the next, the first and the last beyond it). At a limit, below all of these: compound 2.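

In this assay, for the compounds shown here, this is the first single-change pair at the amino nitrogen: isobutyl in place of hydrogen gives a 2.0-fold higher number from compound 1 to compound 4 (0.30 log units; within the scatter), so compound 1 and compound 4 cannot be told apart. This nitrogen can therefore carry an isobutyl group without a change this read-out can resolve, although a single step shows no trend. Nothing measured here accounts for this outcome.

The compounds shown leave open what a longer chain, or a chain ending in an amine or a carboxylic acid, would do on this nitrogen.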